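Trifluoromethoxy in place of trifluoromethyl on a weak inhibitor

A few compounds are considered here, and "the series" means these few. Any claim that something is new, unique, unknown or untested is made for them only; others in the source may bear on it.

Compound 3 `Oc1ccc(-c2cc(-c3ccc(C(F)(F)F)cc3)cc(-c3ccc(O)cc3)n2)cc1` stands at the weak end of everything measured so far. In a functional assay on HCT-15 cells (Homo sapiens) for inhibition (a lower number here means a stronger inhibitor, a higher number a weaker inhibitor), compound 3 reaches only the limit of > 50000 nM. Compound 1 `Oc1ccc(-c2cc(-c3ccc(C(F)(F)F)cc3)cc(-c3cccc(O)c3)n2)cc1` gives 6440 nM in this assay, and the step of an at least 7.7-fold higher number from compound 1 to compound 3 (0.89 log units; beyond the scatter) is the single readable one among the measured changes. Compound 2 `Oc1ccc(-c2cc(-c3cccc(C(F)(F)F)c3)cc(-c3ccc(O)cc3)n2)cc1` also sits at the limit, with > 50000 nM. The step that the two limits leave unreadable from compound 2 to compound 3 therefore tells nothing about direction, which follows from the limit of > 50000 nM in this assay, at which 2 of the 3 values shown sit. Compound 4 `Oc1ccc(-c2cc(-c3ccc(OC(F)(F)F)cc3)cc(-c3ccc(O)cc3)n2)cc1` differs from compound 3 by trifluoromethoxy in place of trifluoromethyl on an aromatic carbon. Among the compounds with values here, no measured step touches trifluoromethoxy, so the expectation rests on compound 3 alone. Compound 4 is expected to remain near the limit, a step of a number no higher from compound 3 to compound 4 (the limit leaves the size open), with an estimated value of 50000 nM in this assay lying between 15000 nM and 150000 nM.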

Compound 4, half-maximal inhibitory concentration: 13900 nM
Beside the measured number, compound 4's estimate is 3.6-fold (0.56 log units) above it, and the stated range ends above it.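

With trifluoromethoxy in place of trifluoromethyl, para to a large group, this position proves able to move the read-out in this assay, giving an at least 3.5-fold lower number from compound 3 to compound 4 (0.55 log units; beyond the scatter). Within the data shown here, this is the first readable step at this substituent, as the earlier change in the placement of trifluoromethyl could not be read. The full size of the new step stays open because compound 3 carries only a limit: the limit of > 50000 nM in this assay, at which 2 of the 4 values shown sit.

The compounds shown leave open how a methoxy group or an amine would read at this position. They also leave open whether trifluoromethoxy would give a similar step alongside the 3-hydroxyphenyl group of compound 1.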